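A Methylphenyl Amide Awaiting Its Cytotoxicity Reading

The source may report more compounds than this note shows. Statements on the series, on what has been measured and on what is new or still open speak of the compounds shown alone.

Of the compounds shown here, three built on one shared core have been tested in a functional assay on HeLa cells (Homo sapiens) for cytotoxicity, read by MTT assay, with a stated time of 24 h; a lower number here means a stronger inhibitor, a higher number a weaker inhibitor. Compound 1, `C=CC1=C(C(=O)NCc2ccccc2)C(c2ccc(OC)cc2)OC1`, gives > 100000 nM, a value that is a limit of the assay rather than a measured number. Compound 2, `C=CC1=C(C(=O)NCc2ccc(C)cc2)C(c2ccc(F)cc2)OC1`, gives > 100000 nM, again a limit. Compound 3, `C=CC1=C(C(=O)NCCC)C(c2ccc(Cl)c(Cl)c2)OC1`, gives > 100000 nM, also a limit. Among the measured compounds shown here, compound 2 thus stands at the limit of > 100000 nM in this assay, at which 3 of the 3 values shown sit; no measured number sets it apart from the other two, and no step between two measured compounds is known.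

Compound 4, `C=CC1=C(C(=O)Nc2cccc(C)c2)C(c2ccc(F)cc2)OC1`, differs from compound 2 in a single place: 3-methylphenyl in place of 4-methylbenzyl on an amide-type nitrogen. For the measured compounds named here, all three measured compounds sit at the same limit, so there is no measured step from which a direction could be read, and the expected change is none beyond the scatter. Compound 4 is expected to give about 100000 nM, within a range from 40000 nM to 300000 nM, and most probably to be reported as a limit once more. This estimate corresponds to an expected step of a number no higher from compound 2 to compound 4 (the limit leaves the size open), essentially no change.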

Compound 4, half-maximal inhibitory concentration: "not active" (no number reported)
Nothing numeric was reported for compound 4; no gap can be computed for the estimate.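

Among the compounds shown here, compound 4 is reported only as "not active", with no number, so no step from compound 2 to compound 4 can be read. Compound 2 remains a limit, not a measured number: the limit of > 100000 nM in this assay, at which 3 of the 4 values shown sit. The compounds shown leave open which changes to the shared core, if any, would give a measured number rather than a limit.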